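Aryl thioether to benzyl ether on a shared core

The source may hold more compounds than are shown below. What is called first, only, known or untested is meant among the compounds shown, and "the series" means these compounds.

Measured so far in a functional assay for inhibition of sodium/hydrogen exchanger (Oryctolagus cuniculus); on this read-out lower numbers stand for stronger inhibition and higher numbers for weaker inhibition:
Compound 1, `Cc1cc(Br)c(S(C)(=O)=O)cc1C(=O)N=C(N)N`, gives 12 nM.
Compound 2, `Cc1cc(Sc2cccc(Cl)c2)c(S(C)(=O)=O)cc1C(=O)N=C(N)N`, gives 37 nM.
Compound 3, `Cc1cc(Sc2ccncc2)c(S(C)(=O)=O)cc1C(=O)N=C(N)N`, gives 13 nM.

Compound 3 holds the second highest of the three numbers. It sits within the scatter of compound 1, as a 1.1-fold higher number from compound 1 to compound 3 (0.03 log units; within the scatter) shows, and is set apart from compound 2 by a 2.8-fold lower number from compound 2 to compound 3 (0.45 log units; beyond the scatter). Compound 4, `Cc1cc(OCc2ccccc2)c(S(C)(=O)=O)cc1C(=O)N=C(N)N`, has not yet been measured in this assay. It differs from compound 3 by benzyloxy in place of (pyridin-4-yl)sulfanyl on an aromatic carbon.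

Two kinds of measured step bear on this change. Putting an aryl sulfanyl group in place of bromo on compound 1 gave a 3.1-fold higher number from compound 1 to compound 2 (0.49 log units; beyond the scatter) with 3-chlorophenyl but only a 1.1-fold higher number from compound 1 to compound 3 (0.03 log units; within the scatter) with pyridin-4-yl, and the direct exchange of the two rings gave a 2.8-fold lower number from compound 2 to compound 3 (0.45 log units; beyond the scatter). Going by the values given here, the group entering compound 4 carries a carbon-only aromatic ring, as in compound 2, yet it is joined through oxygen and one further carbon rather than sulfur, so no measured step matches it exactly. The account therefore expects a modest rise in the number, estimated as a 2.2-fold higher number from compound 3 to compound 4 (0.33 log units; beyond the scatter). Compound 4 is estimated at 28 nM in this assay, with an expected range from 10 nM to 80 nM.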

Compound 4, half-maximal inhibitory concentration: 28 nM
The estimate for compound 4 equals the measured number at the digits printed; the range from low to high includes it.
By their numbers in this assay, from the lowest: compounds 1 and 3 (each within the scatter of the next); then compounds 4 and 2 (each within the scatter of the next).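

Compound 4 shows that this position, ortho to the methylsulfonyl group, can also take a group joined through oxygen and one further carbon, though in this assay benzyloxy gives a 2.3-fold higher number from compound 1 to compound 4 (0.37 log units; beyond the scatter) and a 2.2-fold higher number from compound 3 to compound 4 (0.33 log units; beyond the scatter), both modest. Benzyloxy and (3-chlorophenyl)sulfanyl read alike, with a 1.3-fold lower number from compound 2 to compound 4 (0.12 log units; within the scatter), so among the four compounds the two groups carrying a carbon-only ring stand together, beyond the scatter of both bromo and (pyridin-4-yl)sulfanyl. No measurement offered here explains why these groups differ or why the two with a carbon-only ring agree.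

The change from compound 3 to compound 4 replaces the ring and the link to it together, so the compounds shown leave open how much of the step belongs to each, a question that pyridin-4-ylmethoxy or plain phenylsulfanyl on the shared core would address. Also open, as far as these compounds go, is how this position would respond to an amine, a carboxylic acid or a longer chain such as 2-phenylethoxy.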